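The source may report more compounds than this note shows. Statements on the series, on what has been measured and on what is new or still open speak of the compounds shown alone.

Working notes on the series. Compound 1 `CCCCCCCCNC(=O)[C@@H](NC(=O)c1ccccc1)[C@@H](C)O`, compound 2 `CCCCCCCCNC(=O)[C@@H](NC(=O)c1cc2ccccc2o1)[C@@H](C)O` and compound 3 `C/C=C/C=C/C(=O)N[C@H](C(=O)NCCCCCCCC)[C@@H](C)O` share one core and differ only in the group on the carbonyl carbon of the acyl amide. In a functional assay on SW-620 cells (Homo sapiens) for cytotoxicity, read by MTT assay, with a stated time of 48 h (a higher number here means a weaker inhibitor, a lower number a stronger inhibitor), compound 1 gives 200000 nM, compound 2 gives 200000 nM and compound 3 gives 200000 nM. Compound 3 stands level with both of the others: the step of no change at the digits printed from compound 1 to compound 3 (within the scatter) is flat, the step of no change at the digits printed from compound 2 to compound 3 (within the scatter) is flat, and so is no change at the digits printed from compound 1 to compound 2 (within the scatter). Compound 4 `C/C=C/C=C/C(=O)N[C@H](C(=O)NCCCCCCCCCCCCCC)[C@@H](C)O` is the next member. The change from compound 3 is hexyl in place of hydrogen on a saturated chain carbon, eight bonds along the chain from an amide-type nitrogen. None of the three measured steps touches the octyl chain; all three alter the acyl group, and each was flat. Among the measured compounds shown here, no measured step therefore bears on this change, and the only ground for an expectation is that every change made so far has left the read-out unmoved. The step of a 1.3-fold lower number from compound 3 to compound 4 (0.12 log units; within the scatter) is expected to be small, with a wide range; the chain itself has not been varied among the measured compounds. Compound 4 is estimated at 150000 nM, with a range from 40000 nM to 300000 nM.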

Compound 4, half-maximal inhibitory concentration: 200000 nM
For compound 4 the middle estimate is 1.3-fold (0.12 log units) below the measured one; the measured number falls inside the stated range.
By their numbers in this assay, from the lowest: compounds 1, 2, 3 and 4 (each within the scatter of the next).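

In this assay the step of no change at the digits printed from compound 3 to compound 4 (within the scatter) is the only one among these compounds that alters the chain, and it is as flat as the three steps in the acyl group. The flat picture therefore reaches beyond the acyl group: hexyl in place of hydrogen on a saturated chain carbon, eight bonds along the chain from an amide-type nitrogen, leaves compound 4 level with compound 3. No available evidence accounts for this flat read-out.

Still open, from the compounds shown here alone, is whether a shorter chain, such as butyl in place of octyl, would read differently from compound 3. Also open, going by these compounds, is whether an amine or a carboxylic acid carried on the chain would shift the read-out, since every group varied so far is carbon-based on the chain side.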